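Adding a Methyl Where Three Relatives Stayed Untoxic

A few compounds are considered here, and "the series" means these few. Any claim that something is new, unique, unknown or untested is made for them only; others in the source may bear on it.

Three compounds share one core and differ in a single group. Compound 1 `N#Cc1ccc(Nc2nccc(Oc3ccc(-c4ccc(C#N)cc4)cc3C(F)(F)F)n2)cc1` carries trifluoromethyl. In a functional assay on MT4 cells (Homo sapiens) for cytotoxicity, read by MTT assay, with a stated time of 5 days (a higher number here means that more compound is tolerated, a lower number that less compound is tolerated), compound 1 gives > 273000 nM, which is a limit of the assay rather than a number. Compound 2 `N#Cc1ccc(Nc2nccc(Oc3ccc(-c4ccc(C#N)cc4)cc3Cl)n2)cc1` carries chloro; in this assay compound 2 gives > 295000 nM, again only a limit. Compound 3 `COc1cc(-c2ccc(C#N)cc2)ccc1Oc1ccnc(Nc2ccc(C#N)cc2)n1` carries methoxy; in this assay compound 3 gives > 298000 nM, also a limit. The steps a step that the two limits leave unreadable from compound 1 to compound 2, a step that the two limits leave unreadable from compound 1 to compound 3 and a step that the two limits leave unreadable from compound 2 to compound 3 therefore cannot be read. Compound 2 stands where its two relatives stand: at a limit, with both other values also limits.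

Compound 4 `Cc1cc(-c2ccc(C#N)cc2)cc(Cl)c1Oc1ccnc(Nc2ccc(C#N)cc2)n1` arises from compound 2 by methyl in place of hydrogen on an aromatic carbon, on an aromatic carbon of a six-membered aromatic ring of carbon only, ortho to a large group, meta to the 4-cyanophenyl group and meta to the chloro group. Within the data shown here, none of the measured steps has a readable size, so no direction beyond the scatter can be expected. Among the measured compounds shown here, compound 4 is expected to stay at the same limit, so a step that the limit leaves unreadable from compound 2 to compound 4 is estimated as no step. Compound 4 is estimated at 300000 nM, between 150000 nM and 600000 nM.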

Compound 4, half-maximal cytotoxic concentration: > 285000 nM
Compound 4: only a limit was reported (the forecaster's own chance of this, stated with the estimate: 85%); the middle value does not contradict the limit.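

In this assay compound 4 gives > 285000 nM, which is only a limit. Compound 2 also has only a limit, so the step between compound 2 and compound 4 cannot be read. The compounds shown leave open what concentration, if any, harms these cells, and whether methyl changes it.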